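A Second Aryl Swap on the Amide Nitrogen

This account rests on a few compounds, and the source may have more. Where it says the series, first, only, none or still open, it means among the compounds named here.

Among the measured compounds shown here, compound 2 `Cc1ccc(NC(=O)COc2ccc(/C=C3\SC(=O)NC3=O)cc2)cc1Cl` gives 61800 nM in a functional assay on MCF7 cells (Homo sapiens) for inhibition (a lower number here means a stronger inhibitor of growth, a higher number a weaker inhibitor of growth), the highest of the two numbers measured so far. Compound 1 `Cc1cccc(NC(=O)COc2ccc(/C=C3\SC(=O)NC3=O)cc2)n1` gives 28300 nM in this assay. For the measured compounds named here, the only measured step, a 2.2-fold higher number from compound 1 to compound 2 (0.34 log units; beyond the scatter), concerns an aryl exchange on the same amide-type nitrogen and was modest. Compound 3 `O=C(COc1ccc(/C=C2\SC(=O)NC2=O)cc1)Nc1c(Cl)cccc1Cl` differs from compound 2 by 2,6-dichlorophenyl in place of 3-chloro-4-methylphenyl on an amide-type nitrogen. Going by the values given here, no measured step bears directly on this exchange. Compound 3 is therefore expected to show only a small change: a 1.4-fold lower number from compound 2 to compound 3 (0.14 log units; within the scatter), within or just beyond the scatter in either direction. Compound 3 is estimated at 45000 nM, with a range from 15000 nM to 130000 nM.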

Compound 3, concentration for 50% growth inhibition: 61700 nM
Estimate against measurement, compound 3: 1.4-fold (0.14 log units) below, and the stated range covers the measured number.
By their numbers in this assay, from the lowest: compound 1; then compounds 3 and 2 (each within the scatter of the next).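

On the amide-type nitrogen, 2,6-dichlorophenyl and 3-chloro-4-methylphenyl cannot be told apart in this assay, with a 1.0-fold lower number from compound 2 to compound 3 (0.00 log units; within the scatter). Against 6-methylpyridin-2-yl, 2,6-dichlorophenyl gives a 2.2-fold higher number from compound 1 to compound 3 (0.34 log units; beyond the scatter), so both chlorinated phenyl groups read higher than the pyridine of compound 1, and neither compound goes against this. No measurement shown offers an explanation for these results.

The compounds shown leave open how an unsubstituted phenyl or a pyridin-3-yl on this nitrogen would read. They also leave open whether a carboxylic acid on the aryl group would bring the number down.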